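Thioether series: hydroxy in place of fluoro on the aryl

A few compounds are considered here, and "the series" means these few. Any claim that something is new, unique, unknown or untested is made for them only; others in the source may bear on it.

Measured compounds:
compound 1 `Cn1ncc2c(=O)n(-c3ccccc3)c(COc3cccc(F)c3)nc21` — 8200 nM
compound 2 `CC(Sc1nc2c(cnn2C)c(=O)n1-c1ccccc1)c1cccc(F)c1` — 151 nM

In an assay on isolated protein for inhibition of aldehyde dehydrogenase 1A1 (Homo sapiens) (on this read-out higher numbers stand for weaker inhibition and lower numbers for stronger inhibition), compound 2 gives 151 nM, the lower of the two numbers; compound 1 gives 8200 nM, a gap beyond the scatter. Compound 3 `CC(Sc1nc2c(cnn2C)c(=O)n1-c1ccccc1)c1cccc(O)c1` differs from compound 2 by hydroxy in place of fluoro on an aromatic carbon, at the place meta to a large group. Within the data shown here, no measured pair shows this change, so the step from compound 2 to compound 3 is expected to be small, a modest loss not clearly beyond the scatter, as a 2.0-fold higher number from compound 2 to compound 3 (0.30 log units; within the scatter). Compound 3 is expected in this assay at 300 nM, within 80 nM to 1200 nM.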

Compound 3, half-maximal inhibitory concentration: 130 nM
For compound 3 the middle estimate is 2.3-fold (0.36 log units) above the measured one, within the range that was stated.
By their numbers in this assay, from the lowest: compounds 3 and 2 (each within the scatter of the next); then compound 1.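

Within this assay this place on the aryl ring accepts hydroxy in place of fluoro, with a 1.2-fold lower number from compound 2 to compound 3 (0.07 log units; within the scatter) as the step, so adding a hydrogen-bond donor here gives no change beyond the scatter. Among these compounds, the earlier compounds carried only fluoro at this place, so this is the first reading of a second group there. No measurement at hand bears on why the two groups read alike. As far as these compounds go, whether an amine, a carboxylic acid or a methoxy group at this place would read the same remains open. So does the outcome for plain phenyl, with no group there.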